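This account rests on a few compounds, and the source may have more. Where it says the series, first, only, none or still open, it means among the compounds named here.

In an ADME assay on HT-29 cells (Homo sapiens) for cytotoxicity, read by MTT assay, with a stated time of 72 h (a higher number here means a weaker inhibitor, a lower number a stronger inhibitor), compound 2 (`COc1ccc(C2=C(c3cc(OC)c(OC)c(OC)c3)C(=O)C(OC(C)=O)C2)cc1`) gives < 1 ug/mL as a limit, not a number. Compound 3 (`COc1ccc(C2=C(c3cc(OC)c(OC)c(OC)c3)C(=O)C(O)C2)cc1`) gives < 1 ug/mL as a limit too. Compound 1 (`COc1ccc(C2=C(c3cc(OC)c(OC)c(OC)c3)C(=O)C(OC(C)=O)C2)cc1OC(C)C`) gives > 100 ug/mL as a limit as well. Compound 2 thus sits at the lower limit, shared with compound 3, and its true value is not known.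

Compound 4 (`COc1ccc(C2=C(c3cc(OC)c(OC)c(OC)c3)C(=O)C(OC(C)=O)C2)cc1F`) differs from compound 2 by one change (fluoro in place of hydrogen on an aromatic carbon): fluoro in place of hydrogen on an aromatic carbon, ortho to a methoxy group. The closest measured evidence is the large step of an at least 100-fold lower number from compound 1 to compound 2 (2.00 log units; beyond the scatter) in which hydrogen replaces isopropoxy at that same place. The step that the two limits leave unreadable from compound 2 to compound 3 lies elsewhere, on an oxygen on a saturated carbon, and gives no readable size. Fluoro brings only 1 heavy atom, so the large step of an at least 100-fold lower number from compound 1 to compound 2 (2.00 log units; beyond the scatter) is not expected to recur.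

The estimated step is a step that the limit leaves unreadable from compound 2 to compound 4 and no change beyond the scatter is expected. Compound 4 is estimated at 0.7 ug/mL with a range from 0.1 ug/mL to 5 ug/mL as an expected value.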

Compound 4, half-maximal inhibitory concentration: < 1 ug/mL
Compound 4 was reported as a limit (the forecaster's own chance of this, stated with the estimate: 65%); the middle value does not contradict the limit.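

In this assay, fluoro is a second group, after hydrogen, that gives a large step away from isopropoxy at this place on the aromatic carbon ortho to a methoxy group: an at least 100-fold lower number from compound 1 to compound 4 (2.00 log units; beyond the scatter). The step for hydrogen at the same place is of matching printed size: an at least 100-fold lower number from compound 1 to compound 2 (2.00 log units; beyond the scatter). Among the three groups seen here, only isopropoxy goes with the high limit, but the steps from compound 2 to compound 3 and from compound 2 to compound 4 cannot be read, because those values share one limit: the limit of < 1 ug/mL in this assay, at which 3 of the 4 values shown sit.

As far as these compounds go, the order among compound 2, compound 3 and compound 4 stays open. Also open, from the compounds shown here alone, is how large a group this place tolerates short of isopropoxy, which a hydroxyl, an ethoxy or an amine there would begin to show.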